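The source may report more compounds than this note shows. Statements on the series, on what has been measured and on what is new or still open speak of the compounds shown alone.

Compound 3, `COc1nc(C)c(Nc2nc(Cl)cn([C@H](COc3cc(Br)ccn3)C3CC3)c2=O)cc1C`, gives 1.5 nM in an assay on frontal cortex for displacement of a labelled ligand from corticotropin-releasing factor receptor 1 (Rattus norvegicus), with a stated time of 2 h; a higher number here means a weaker inhibitor, a lower number a stronger inhibitor. Within the data shown here, it stands together with compound 1, `COc1nc(C)c(Nc2nc(Cl)cn([C@H](COC(=O)Nc3ccccc3Cl)C3CC3)c2=O)cc1C`, which gives 1.5 nM, at the lowest of the three numbers known; compound 2, `CCCNC(=O)OC[C@H](C1CC1)n1cc(Cl)nc(Nc2cc(C)c(OC)nc2C)c1=O`, gives 10 nM. The two groups at the oxygen on the saturated carbon that differ widely in kind still come out alike, as shown by no change at the digits printed from compound 1 to compound 3 (within the scatter), whereas the propylcarbamoyl group sits apart, as shown by a 6.7-fold lower number from compound 2 to compound 3 (0.82 log units; beyond the scatter) and a 6.7-fold higher number from compound 1 to compound 2 (0.82 log units; beyond the scatter).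

Compound 4, `COc1nc(C)c(Nc2nc(Cl)cn([C@H](COc3ccc(C(F)(F)F)cn3)C3CC3)c2=O)cc1C`, differs from compound 3 by 5-(trifluoromethyl)pyridin-2-yl in place of 4-bromopyridin-2-yl on an oxygen on a saturated carbon. This step keeps the pyridinyl ether and exchanges one substituent on the ring for another. Among the measured compounds shown here, no measured step compares two pyridinyl ethers; the measured steps at this oxygen only show that the (2-chlorophenyl)carbamoyl and the 4-bromopyridin-2-yl groups give the same number, so the data do not tell how a change within the ring itself plays out. Given the small spread between compound 1 and compound 3, compound 4 is expected to land near compound 3, with a step of a 1.3-fold higher number from compound 3 to compound 4 (0.12 log units; within the scatter) in this assay that stays within the scatter. The estimate for compound 4 is 2 nM, within 0.7 nM to 6 nM.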

Compound 4, half-maximal inhibitory concentration: 1.6 nM
Compound 4: middle estimate off by 1.3-fold (0.10 log units), on the high side; measured number inside the range.
By their numbers in this assay, from the lowest: compounds 1, 3 and 4 (each within the scatter of the next); then compound 2.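

Among these compounds, compound 4 gives the one comparison here between two pyridinyl ethers, and in this assay the exchange of 4-bromopyridin-2-yl for 5-(trifluoromethyl)pyridin-2-yl, with 10 heavy atoms entering and 7 leaving, comes to a 1.1-fold higher number from compound 3 to compound 4 (0.03 log units; within the scatter) and so does not separate the two rings. Among the compounds shown here, the match between a pyridinyl ether and the (2-chlorophenyl)carbamoyl group therefore no longer rests on a single ether, since the step is a 1.1-fold higher number from compound 1 to compound 4 (0.03 log units; within the scatter), while propylcarbamoyl remains the group that goes against this likeness, with a 6.3-fold lower number from compound 2 to compound 4 (0.80 log units; beyond the scatter) as a second step of nearly the same size as the one to compound 3. Nothing among the data shown accounts for why these groups on the oxygen come out alike or why propylcarbamoyl stands apart.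

The compounds shown leave open whether the same numbers would hold with a bare pyridin-2-yl ring, or with a nitrile or a methoxy group on that ring. They also leave open what a small methyl group, a primary amine or a carboxylic acid-bearing chain would do on this oxygen on a saturated carbon.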